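Replacing a thiazolyl group with trifluoroethoxy: permeability outlook

The compounds below may be only part of what the source reports. "The series", "measured", "known", "first", "only" and "open" are said of these compounds alone.

Of the compounds shown here, three sharing one core have been measured in an ADME assay on LLC-PK1 cells (Sus scrofa) for permeability; on this read-out higher numbers stand for higher permeability and lower numbers for lower permeability. Compound 1 `COc1ccccc1C(=O)NC(=O)Nc1ccc(-c2ccccc2)c(C(F)(F)F)c1` gives < 1 10^-6 cm/s, which is only a limit, not a number: the limit of < 1 10^-6 cm/s in this assay, at which 1 of the 3 values shown sits. Compound 2 `COc1ccccc1C(=O)NC(=O)Nc1ccc(-c2ccccc2)c(C(C)C)c1` gives 1.2 10^-6 cm/s in this assay, and compound 3 `COc1ccccc1C(=O)NC(=O)Nc1ccc(-c2nccs2)c(C(F)(F)F)c1` gives 12 10^-6 cm/s. The change from compound 1 to compound 2 brought an at least 1.2-fold higher number from compound 1 to compound 2 (0.07 log units; that floor lies within the scatter), whereas the change from compound 1 to compound 3 brought an at least 12-fold higher number from compound 1 to compound 3 (1.07 log units; beyond the scatter). Compound 3 therefore stands at the highest of the two numbers given, with compound 2 the nearest, and its gap to compound 2 lies beyond the scatter.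

Compound 4 `COc1ccccc1C(=O)NC(=O)Nc1ccc(OCC(F)(F)F)c(C(F)(F)F)c1` is not yet measured. It differs from compound 3 in one place: 2,2,2-trifluoroethoxy in place of 1,3-thiazol-2-yl on an aromatic carbon. Going by the values given here, only the step from compound 1 to compound 3 concerns this position, and it exchanged one ring for another, whereas here the ring is removed and a chain enters; no measured step shows that kind of change. The 1,3-thiazol-2-yl group that made compound 3 the high point leaves, so a drop is expected, though of uncertain size. Compound 4 is expected to give about 5 10^-6 cm/s, with a range from 1.5 10^-6 cm/s to 15 10^-6 cm/s. The expected step from compound 3 to compound 4 is thus a 2.4-fold lower number from compound 3 to compound 4 (0.38 log units; beyond the scatter).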

Compound 4, apparent permeability: < 1 10^-6 cm/s
Compound 4: no number, only a limit; the forecaster's own chance of this, stated with the estimate: 15%; at least 5.0-fold (0.69 log units) between middle value and limit.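

In this assay, putting the open chain 2,2,2-trifluoroethoxy in place of 1,3-thiazol-2-yl brought an at least 12-fold lower number from compound 3 to compound 4 (1.07 log units; beyond the scatter), the first step shown in which a ring at this position gives way to a chain. With the trifluoromethyl group kept, 1,3-thiazol-2-yl is now the only one of the three groups shown at this position to give a value above the limit, and the phenyl ring of compound 1 shows that the presence of a ring alone does not ensure such a value. The step from compound 1 to compound 4 cannot be read, because both compounds sit at the same limit: the limit of < 1 10^-6 cm/s in this assay, at which 2 of the 4 values shown sit.

The compounds shown leave open which part of 1,3-thiazol-2-yl matters, since its nitrogen, its sulfur and its five-membered ring always change together, and a pyridine ring, an oxazole ring or a simple amine at this position would help to separate them. They also leave open whether a different chain, such as a plain ethoxy or a longer chain ending in an alcohol, would stay at the limit as 2,2,2-trifluoroethoxy does.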